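Nitro to amino on two trimethoxyphenyl cores

A few compounds are considered here, and "the series" means these few. Any claim that something is new, unique, unknown or untested is made for them only; others in the source may bear on it.

Measured so far:
Compound 1, `COc1ccc(-n2ccnc2-c2cc(OC)c(OC)c(OC)c2)cc1[N+](=O)[O-]`, gives 2500 nM in a functional assay on HeLa cells (Homo sapiens) for antiproliferative activity, read by MTT assay, with a stated time of 72 h; a higher number here means a weaker inhibitor, a lower number a stronger inhibitor.
Compound 2, `COc1ccc(-n2ccnc2-c2cc(OC)c(OC)c(OC)c2)cc1N`, gives 80 nM in this assay.
Compound 3, `COc1ccc(OC(=O)c2cc(OC)c(OC)c(OC)c2)cc1[N+](=O)[O-]`, gives only a limit of the assay in this assay, namely > 100000 nM.

The change from compound 1 to compound 2 is amino in place of nitro on an aromatic carbon. It made a 31-fold lower number from compound 1 to compound 2 (1.49 log units; beyond the scatter).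

Compound 4, `COc1ccc(OC(=O)c2cc(OC)c(OC)c(OC)c2)cc1N`, is not yet measured. It differs from compound 3 by amino in place of nitro on an aromatic carbon, the same change made on the other core; the two place descriptions read alike. How the core of compound 1 and the core of compound 3 differ is not broken down here; the two values only show compound 1 giving a number and compound 3 giving a limit.

For compound 4 the step of an at least 5.0-fold lower number from compound 3 to compound 4 (0.69 log units; beyond the scatter) is expected, resting on a 31-fold lower number from compound 1 to compound 2 (1.49 log units; beyond the scatter) and on (the limit of > 100000 nM in this assay, at which 1 of the 3 values shown sits), where the starting point is a limit rather than a number, so the start of the step is itself uncertain. Compound 4 is estimated at 20000 nM, between 2000 nM and 100000 nM, with a real chance that the assay again reports only a limit.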

Compound 4, half-maximal inhibitory concentration: > 100000 nM
Compound 4: no number, only a limit; the forecaster's own chance of this, stated with the estimate: 40%; middle value at least 5.0-fold (0.69 log units) from the limit.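

Compound 3 and compound 4 both give only a limit in this assay, so no step can be read for amino in place of nitro on this core: the limit of > 100000 nM in this assay, at which 2 of the 4 values shown sit.

The compounds shown leave open whether that change does anything on the core of compound 3, where neither compound has a number to set against the step from the core of compound 1.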